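A few compounds are considered here, and "the series" means these few. Any claim that something is new, unique, unknown or untested is made for them only; others in the source may bear on it.

Measured so far:
compound 1, `Cc1cc(O)cc(-c2nn(CC#N)cc2-c2ccnc(-c3ccc(Oc4ccccc4)cc3)c2)c1`, 84% in a functional assay on A498 cells (Homo sapiens) for cytotoxicity, read by sulforhodamine B assay, with a stated time of 48 h, tested at 100 nM; on this read-out lower numbers stand for a stronger effect and higher numbers for a weaker effect at the one concentration tested;
compound 2, `COc1cc(C)cc(-c2nn(CC#N)cc2-c2ccnc(-c3ccc(N(C)C)cc3)c2)c1`, -8% in this assay.

On these two numbers compound 2 stands lowest; its nearest neighbour is compound 1, whose value sits far higher, beyond the usual scatter. For the measured compounds named here, compound 1 and compound 2 differ in more than one place, so no single step between them is recorded; only their two values can be set side by side.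

Compound 3, `Cc1cc(O)cc(-c2nn(CC#N)cc2-c2ccnc(-c3ccc(N(C)C)cc3)c2)c1`, has not yet been measured. Compared with compound 2 the change is hydrogen in place of methyl on an oxygen on an aromatic ring. Compound 3 keeps the rest of compound 2 unchanged, while it shares the hydroxy group with compound 1. Going by the values given here, with no recorded step of this kind, the direction is uncertain; the value is expected to rise from compound 2 toward a weaker effect, by a number 38 percentage points higher from compound 2 to compound 3 (beyond the scatter), while staying well under the value of compound 1. For compound 3 the expected value in this assay is 30%, within a range from -10% to 85%.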

Compound 3, a percentage reported as activity, at one concentration (the size of the read-out at that concentration, not a potency): 92%
Beside the measured number, compound 3's estimate is 62 percentage points below it, outside the stated range (above it).
By their numbers in this assay, from the lowest: compound 2; then compounds 1 and 3 (each within the scatter of the next).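

In this assay the change from methoxy to hydroxy on the aromatic ring is a large step (a number 100 percentage points higher from compound 2 to compound 3 (beyond the scatter)), so the strong effect of compound 2 at this concentration depends on that methyl on the oxygen, at least with dimethylamino held constant. With the hydroxy group in place, the other change, dimethylamino in place of phenoxy, gives a step within the scatter (a number 8 percentage points higher from compound 1 to compound 3 (within the scatter)), so this pair cannot be told apart. Nothing available here explains why losing one methyl has such a large effect.

The compounds shown leave open whether a longer chain on that oxygen, such as ethoxy, or an amine in place of the oxygen, would retain the effect. They also leave open whether phenoxy would be tolerated alongside methoxy.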